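The source may hold more compounds than are shown below. What is called first, only, known or untested is meant among the compounds shown, and "the series" means these compounds.

Compound 1 `CC(C)[C@H](NC(=O)COc1cccc2ccccc12)C(=O)N[C@@H](CC(=O)O)C(=O)CSc1nc(-c2ccccc2)cs1` gives > 200000 nM in a functional assay on Jurkat cells (Homo sapiens) for inhibition (a lower number here means a stronger inhibitor, a higher number a weaker inhibitor), which is a limit of the assay and not a number; compound 1 therefore stands at the limit of > 200000 nM in this assay, at which 2 of the 3 values shown sit. Compound 2 `CC(C)[C@H](NC(=O)COc1cccc2ccccc12)C(=O)N[C@@H](CC(=O)O)C(=O)COn1nnc2ccccc21` gives > 200000 nM in this assay, again a limit. Compound 3 `CC(C)[C@H](NC(=O)COc1cccc2ccccc12)C(=O)N[C@@H](CC(=O)O)C(=O)COc1ccnc(C(F)(F)F)n1` gives 37000 nM in this assay. The step that the two limits leave unreadable from compound 1 to compound 2 cannot be read, whereas an at least 5.4-fold lower number from compound 1 to compound 3 (0.73 log units; beyond the scatter) and an at least 5.4-fold lower number from compound 2 to compound 3 (0.73 log units; beyond the scatter) both run to a lower number.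

Compound 4 `CC(C)[C@H](NC(=O)COc1cccc2ccccc12)C(=O)N[C@@H](CC(=O)O)C(=O)COc1cc(C(F)(F)F)ncn1` differs from compound 1 by (6-(trifluoromethyl)pyrimidin-4-yl)oxy in place of (4-phenyl-1,3-thiazol-2-yl)sulfanyl on a saturated chain carbon bound to a carbonyl carbon. The closest measured step is an at least 5.4-fold lower number from compound 1 to compound 3 (0.73 log units; beyond the scatter), where a trifluoromethyl-bearing pyrimidinyloxy group likewise replaced the same sulfanyl group; a step of similar size toward a lower number is therefore expected as an at least 5.0-fold lower number from compound 1 to compound 4 (0.69 log units; beyond the scatter). Compound 4 is expected at 40000 nM, with a range from 10000 nM to 200000 nM.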

Compound 4, half-maximal inhibitory concentration: > 200000 nM
Compound 4 was reported as a limit; the forecaster's own chance of this, stated with the estimate: 25%; middle value at least 5.0-fold (0.69 log units) from the limit.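

In this assay, 6-(trifluoromethyl)pyrimidin-4-yl in place of 2-(trifluoromethyl)pyrimidin-4-yl on the oxygen gives an at least 5.4-fold higher number from compound 3 to compound 4 (0.73 log units; beyond the scatter), so a trifluoromethyl-bearing pyrimidinyloxy group alone does not secure a measurable value; the isomer matters. The steps to compound 4 from compound 1 and compound 2 cannot be read. The value of compound 4 is a limit, and the series gathers there: the limit of > 200000 nM in this assay, at which 3 of the 4 values shown sit.

Going by these compounds, how far compound 4 lies past its limit stays open. Also open, on these data alone, is whether an amine or a methoxy group in place of the trifluoromethyl of compound 3 would keep a measurable value.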